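This account rests on a few compounds, and the source may have more. Where it says the series, first, only, none or still open, it means among the compounds named here.

Of the compounds shown here, three share one core and have been tested in an ADME assay on PC-3 cells (Homo sapiens) for cytotoxicity, read by WST assay, tested at 100 uM; on this read-out higher numbers stand for more inhibition at the one concentration tested (going by the name of the read-out) and lower numbers for less inhibition. Compound 1 `COC(=O)c1cccc(NC(=O)C2CCCN(C(=O)c3cc(C(F)(F)F)cc(C(F)(F)F)c3)C2)c1` gives 0% in this assay. Compound 2 `O=C(Nc1cccc(Oc2ccccc2)c1)C1CCCN(C(=O)c2cc(C(F)(F)F)cc(C(F)(F)F)c2)C1` gives 1%, and compound 3 `O=C(Nc1cccc(Cc2ccccc2)c1)C1CCCN(C(=O)c2cc(C(F)(F)F)cc(C(F)(F)F)c2)C1` gives 0%. All three swaps sit at the same aromatic carbon: a number 1 percentage points higher from compound 1 to compound 2 (within the scatter), no change at the digits printed from compound 1 to compound 3 (within the scatter) and a number 1 percentage points lower from compound 2 to compound 3 (within the scatter). Compound 3 thus stands level with compound 1 at the digits shown, and its gap to compound 2 also lies within the scatter.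

Compound 4 `Cn1cnnc1-c1cccc(NC(=O)C2CCCN(C(=O)c3cc(C(F)(F)F)cc(C(F)(F)F)c3)C2)c1` is the next step from compound 3. The change is 4-methyl-4H-1,2,4-triazol-3-yl in place of benzyl on an aromatic carbon. Among the measured compounds shown here, no measured step introduces a five-membered aromatic ring with hetero atoms, so none bears directly on this change; the three steps that exchange groups at this carbon were all within the scatter. It is therefore expected that a number 1 percentage points higher from compound 3 to compound 4 (within the scatter) lies within the scatter as well. For compound 4 the estimate in this assay is 1%, with a range from -10% to 12%.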

Compound 4, a percentage reported as inhibition, at one concentration (the size of the read-out at that concentration, not a potency): 0%
Beside the measured number, compound 4's estimate is 1 percentage points above it, within the range that was stated.
By their numbers in this assay, from the lowest: compounds 1, 3, 4 and 2 (each within the scatter of the next).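

In this assay, a five-membered aromatic ring with hetero atoms at this aromatic carbon gives no step beyond the scatter against any earlier group: no change at the digits printed from compound 3 to compound 4 (within the scatter), a number 1 percentage points lower from compound 2 to compound 4 (within the scatter) and no change at the digits printed from compound 1 to compound 4 (within the scatter). The earlier compounds shown here carried only methoxycarbonyl, phenoxy and benzyl here, so 4-methyl-4H-1,2,4-triazol-3-yl, with its 3 hydrogen-bond acceptors where benzyl has 0, widens the range of groups at this position that leave the read-out within the scatter. No outside measurement is available to account for this result.

The compounds shown leave open whether any group at this carbon, such as an amine or a carboxylic acid, would give a step beyond the scatter. They also leave open whether a change elsewhere on the shared core would do so, as every step here lies at this one carbon.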